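Cytotoxicity notes on the series: compound 3 to compound 4

The source may hold more compounds than are shown below. What is called first, only, known or untested is meant among the compounds shown, and "the series" means these compounds.

Compound 1, `CCCCSc1cc2[nH]c(C3CCCCC3)nc2cc1NC(=O)c1ccc(F)cc1F`, gives > 200000 nM, a limit of the assay and not a number.
Compound 2, `C=CCCC(=O)Nc1cc2nc(C3CCCCC3)[nH]c2cc1Oc1ccc(F)cc1`, gives > 200000 nM, likewise a limit of the assay.
Compound 3, `Cc1ccc(C(=O)Nc2cc3nc(C4CCCCC4)[nH]c3cc2Oc2ccc(F)cc2)cc1`, gives 26000 nM.

All three values come from an ADME assay on Vero cells (Chlorocebus sabaeus) for cytotoxicity, read by MTT assay, with a stated time of 2 days; a lower number here means a stronger inhibitor, a higher number a weaker inhibitor. Among the measured compounds shown here, compound 3 holds the only number in this assay; the two other values are limits, as summed up in the limit of > 200000 nM in this assay, at which 2 of the 3 values shown sit. For the measured compounds named here, the one measured step is an at least 7.6-fold lower number from compound 2 to compound 3 (0.88 log units; beyond the scatter), a change at the carbonyl carbon, not at the aromatic carbon touched next.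

Compound 4, `CCCCSc1cc2[nH]c(C3CCCCC3)nc2cc1NC(=O)c1ccc(C)cc1`, is not yet measured in this assay. It differs from compound 3 in one place: butylsulfanyl in place of 4-fluorophenoxy on an aromatic carbon. Going by the values given here, no measured step covers this change, so the size of the step in this assay is open. Compound 1, which also carries butylsulfanyl, gives only the limit > 200000 nM, but its amide differs from that of compound 4, so it does not fix the outcome. On balance a higher number than that of compound 3 is expected for compound 4, with a real chance that only a limit is returned, and the expected step is a 2.7-fold higher number from compound 3 to compound 4 (0.43 log units; beyond the scatter). The estimate for compound 4 in this assay is 70000 nM, with a range from 15000 nM to 200000 nM.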

Compound 4, half-maximal inhibitory concentration: > 200000 nM
Compound 4: no number, only a limit; the forecaster's own chance of this, stated with the estimate: 40%; middle value at least 2.8-fold (0.45 log units) away from the limit.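

In this assay, among the compounds shown here, butylsulfanyl in place of 4-fluorophenoxy on the aromatic carbon ortho to the ((4-methylphenyl)carbonyl)amino group gives an at least 7.6-fold higher number from compound 3 to compound 4 (0.88 log units; beyond the scatter), the first readable step at this position, and its size is only a minimum, since the value of compound 4 is a limit of the assay and not a number. The earlier step showed a measurable number appearing with a change at the carbonyl carbon; this one shows that, with the 4-methylphenyl amide kept, the number also depends on the group at this aromatic carbon, so compound 3 loses it with a change at either of these two places. Among the compounds shown, compound 3 therefore remains the only one with a number: the limit of > 200000 nM in this assay, at which 3 of the 4 values shown sit.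

On these data alone, the step from compound 1 to compound 4 joins two limits and cannot be read, so the effect of 4-methylphenyl against 2,4-difluorophenyl on the carbonyl carbon, with butylsulfanyl in place, stays open. Also open, as far as these compounds go, is whether a shorter chain such as methylsulfanyl, or an amine, on this aromatic carbon would give a number in this assay.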